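The source may report more compounds than this note shows. Statements on the series, on what has been measured and on what is new or still open speak of the compounds shown alone.

In a functional assay on PC-3 cells (Homo sapiens) for antiproliferative activity, read by MTT assay, with a stated time of 72 h; a higher number here means a weaker inhibitor, a lower number a stronger inhibitor:
Compound 1 `CCCCCCCCCCNC[C@@H]1OC[C@H](N)[C@@H]1O`: 11900 nM
Compound 2 `CCCCCCCCNC[C@@H]1OC[C@H](N)[C@@H]1O`: 13800 nM
Compound 3 `CCCCCCCNC[C@@H]1OC[C@H](N)[C@@H]1O`: 22400 nM

Compound 3 stands within the scatter of both other compounds, with a 1.6-fold higher number from compound 2 to compound 3 (0.21 log units; within the scatter) and a 1.9-fold higher number from compound 1 to compound 3 (0.27 log units; within the scatter). Compound 4 `CCCCCCCCCCCNC[C@@H]1OC[C@H](N)[C@@H]1O` differs from compound 3 by butyl in place of hydrogen on a saturated chain carbon, seven bonds along the chain from an amine nitrogen. Within the data shown here, the closest precedent is the change at that same carbon, a 1.9-fold higher number from compound 1 to compound 3 (0.27 log units; within the scatter), and the smaller 1.2-fold higher number from compound 1 to compound 2 (0.06 log units; within the scatter) adds little. On that precedent, a modest move to a lower number is expected, near the edge of the scatter. The estimated step is a 2.2-fold lower number from compound 3 to compound 4 (0.35 log units; beyond the scatter). For compound 4 the expected value is 10000 nM, with an estimated range of 5000 nM to 19000 nM.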

Compound 4, half-maximal inhibitory concentration: 3330 nM
Beside the measured number, compound 4's estimate is 3.0-fold (0.48 log units) above it; measured number below the stated range.
By their numbers in this assay, from the lowest: compound 4; then compounds 1, 2 and 3 (each within the scatter of the next).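

In this assay, among these compounds, the earlier chain changes had all stayed within the scatter, and adding butyl at this carbon is the first to go beyond it, with a 6.7-fold lower number from compound 3 to compound 4 (0.83 log units; beyond the scatter). The same holds for propyl eight bonds along the chain, with a 4.1-fold lower number from compound 2 to compound 4 (0.62 log units; beyond the scatter), and for methyl on a saturated chain carbon, with a 3.6-fold lower number from compound 1 to compound 4 (0.55 log units; beyond the scatter). Those larger steps still do not separate the change from its earlier readings, as the gap between them lies within the scatter: the same change on two cores in this assay, a 1.9-fold higher number (0.27 log units; within the scatter) from compound 1 to compound 3 and a 4.1-fold higher number (0.62 log units; beyond the scatter) from compound 4 to compound 2, 2.2-fold (0.34 log units) apart, within the scatter of two such steps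

The compounds shown leave open whether a longer chain would lower the number further or reverse the trend. They also leave open whether a chain ending in a carboxylic acid or an amine would keep this gain.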